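Indol-3-yl in place of pyrrol-2-yl on the enone carbonyl

The compounds below may be only part of what the source reports. "The series", "measured", "known", "first", "only" and "open" are said of these compounds alone.

Compound 3 `COc1ccc(-c2cc3ccccc3nc2/C=C/C(=O)c2ccc[nH]2)cc1` carries a 1H-pyrrol-2-yl group on the carbonyl carbon of the shared core. In a functional assay on MDA-MB-231 cells (Homo sapiens) for antiproliferative activity, read by XTT assay, with a stated time of 72 h (a higher number here means a weaker inhibitor, a lower number a stronger inhibitor), compound 3 reaches only the limit of the assay, > 10000 nM, and no number is known for it. Its two neighbours with the same core are measured: compound 1 `COc1ccc(-c2cc3ccccc3nc2/C=C/C(=O)c2ccco2)cc1` with a furan-2-yl group gives 630 nM in this assay, and compound 2 `COc1ccc(-c2cc3ccccc3nc2/C=C/C(=O)c2ccccn2)cc1` with a pyridin-2-yl group gives 740 nM. The steps to the pyrrole are both large: an at least 15-fold higher number from compound 1 to compound 3 (1.20 log units; beyond the scatter) and an at least 13-fold higher number from compound 2 to compound 3 (1.13 log units; beyond the scatter), whereas a 1.2-fold higher number from compound 1 to compound 2 (0.07 log units; within the scatter).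

Compound 4 `COc1ccc(-c2cc3ccccc3nc2/C=C/C(=O)c2c[nH]c3ccccc23)cc1` differs from compound 3 in one place: 1H-indol-3-yl in place of 1H-pyrrol-2-yl on a carbonyl carbon. For the measured compounds named here, no measured step tells how an 1H-indol-3-yl group behaves here; the only related steps are the two large losses on going to the pyrrole, and the starting point is itself a limit (the limit of > 10000 nM in this assay, at which 1 of the 3 values shown sits). Compound 4 is therefore expected to stay weak, with an estimated 8000 nM between 1500 nM and 30000 nM, meaning an expected at least 1.2-fold lower number from compound 3 to compound 4 (0.09 log units; that floor lies within the scatter).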

Compound 4, half-maximal inhibitory concentration: > 10000 nM
Compound 4: only a limit was reported; the forecaster's own chance of this, stated with the estimate: 45%; middle value at least 1.2-fold (0.09 log units) from the limit.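

In this assay, replacing either measured group with 1H-indol-3-yl on the carbonyl carbon brings a large loss: an at least 15-fold higher number from compound 1 to compound 4 (1.20 log units; beyond the scatter), and an at least 13-fold higher number from compound 2 to compound 4 (1.13 log units; beyond the scatter). The loss seen with 1H-pyrrol-2-yl is therefore not confined to that one group, and compound 3 and compound 4, whose groups each count a hydrogen-bond donor, both stand at a limit of the assay rather than at a number. The step between these two compounds cannot be read, but the added six-membered aromatic ring of carbon does not bring compound 4 to a measurable value: the limit of > 10000 nM in this assay, at which 2 of the 4 values shown sit.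

On these data alone, how far compound 3 and compound 4 actually differ stays open. So does how a 1-methyl-1H-pyrrol-2-yl, 1-methyl-1H-indol-3-yl, thiophen-2-yl or phenyl group would behave on this carbonyl carbon.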